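Shifting the methoxy group on the benzylamide side chain

The source may hold more compounds than are shown below. What is called first, only, known or untested is meant among the compounds shown, and "the series" means these compounds.

Compound 1, `COc1ccc(CNC(=O)c2nc(-c3ccc(F)cc3)n(CC[C@@H](O)C[C@@H](O)CC(=O)O)c2C2CC2)cc1F`, is the starting point. In a functional assay on L6 cells (Rattus norvegicus) for inhibition, read by scintillation counting, with a stated time of 3 h (on this read-out lower numbers stand for stronger inhibition and higher numbers for weaker inhibition), compound 1 gives 890 nM, the lowest of the two numbers obtained here. Compound 3, `O=C(O)C[C@H](O)C[C@H](O)CCn1c(-c2ccc(F)cc2)nc(C(=O)NCc2ccc(F)cc2)c1C1CC1`, gives 1620 nM in this assay. Compound 2, `CN(C)S(=O)(=O)c1ccc(CNC(=O)c2nc(-c3ccc(F)cc3)n(CC[C@@H](O)C[C@@H](O)CC(=O)O)c2C2CC2)cc1`, is reported in this assay only as > 100000 nM, which is a limit of the assay and not a number.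

Two measured steps start from compound 1. Swapping the 3-fluoro-4-methoxyphenyl for 4-fluorophenyl gave a 1.8-fold higher number from compound 1 to compound 3 (0.26 log units; within the scatter). Swapping it for 4-(dimethylsulfamoyl)phenyl gave an at least 110-fold higher number from compound 1 to compound 2 (2.05 log units; beyond the scatter), consistent with the limit of > 100000 nM in this assay, at which 1 of the 3 values shown sits.

Compound 4, `COc1ccccc1CNC(=O)c1nc(-c2ccc(F)cc2)n(CC[C@@H](O)C[C@@H](O)CC(=O)O)c1C1CC1`, differs from compound 1 in one place: 2-methoxyphenyl in place of 3-fluoro-4-methoxyphenyl on a saturated chain carbon bound to an amide-type nitrogen. This is a small change, closer in kind to the step to compound 3 than to the step to compound 2. For compound 4 the expected outcome is therefore a modest step, a 1.8-fold higher number from compound 1 to compound 4 (0.25 log units; within the scatter), toward a somewhat higher number. The estimate for compound 4 in this assay is 1600 nM, within a range from 500 nM to 6000 nM.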

Compound 4, half-maximal inhibitory concentration: 10700 nM
Compound 4: middle estimate off by 6.7-fold (0.83 log units), on the low side; measured number outside the range, above it.
By their numbers in this assay, from the lowest: compounds 1 and 3 (each within the scatter of the next); then compound 4. At a limit, above all of these: compound 2.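

Until now only the much larger 4-(dimethylsulfamoyl)phenyl had moved the number far, yet the small swap to 2-methoxyphenyl also gives a 12-fold higher number from compound 1 to compound 4 (1.08 log units; beyond the scatter), so this place on the side chain responds strongly even to a small change. Carrying a methoxy group does not by itself keep the number low: 4-fluorophenyl has no methoxy group, and the change from it still gives a 6.6-fold higher number from compound 3 to compound 4 (0.82 log units; beyond the scatter). Compound 2 stands at a limit and not a number, so the remaining step, an at least 9.3-fold lower number from compound 2 to compound 4 (0.97 log units; beyond the scatter), is only a bound: the limit of > 100000 nM in this assay, at which 1 of the 4 values shown sits.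

Compound 4 both loses the fluoro group and carries its methoxy group elsewhere on the ring, and the compounds shown do not separate these two changes; nothing here explains the rise in number. Going by these compounds, whether a hydroxy group or an amine in place of the methoxy group would be tolerated also remains open.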